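The compounds below may be only part of what the source reports. "The series", "measured", "known", "first", "only" and "open" are said of these compounds alone.

Three compounds share one core and differ only in the group attached to the thiocarbonyl carbon. Compound 1 `Nc1ccccc1NC(=O)c1ccc(CSC(=S)N2CCc3ccccc32)cc1`, compound 2 `Nc1ccccc1NC(=O)c1ccc(CSC(=S)N2CCCc3ccccc32)cc1` and compound 3 `N#Cc1ccc(N2CCN(C(=S)SCc3ccc(C(=O)Nc4ccccc4N)cc3)CC2)cc1` were each tested in a functional assay on MGC-803 cells (Homo sapiens) for antiproliferative activity, read by CCK-8 assay, with a stated time of 72 h, tested at 2 uM; a lower number here means a weaker effect, a higher number a stronger effect of the compound at the concentration tested. There compound 1 gives 44%, compound 2 gives 38.5%, and compound 3 gives 34.5%. The number for compound 3 is the lowest of the three, yet its gaps to compound 2 and to compound 1 are both within the usual scatter, so the three cannot be told apart on these data. For the measured compounds named here, the only single-place step measured is a number 5.5 percentage points lower from compound 1 to compound 2 (within the scatter), which is also within the scatter.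

Compound 4 `CN1CCN(C(=S)SCc2ccc(C(=O)Nc3ccccc3N)cc2)CC1` differs from compound 3 as follows: methyl in place of 4-cyanophenyl on an amine nitrogen in a ring. Going by the values given here, no measured step touches that amine nitrogen in a ring, and the one step that exists shows no effect beyond the scatter, so a step beyond the scatter in this assay is not expected in either direction. For compound 4 a value of 33% is expected, with a range from 18% to 48%. This estimate means an expected step of a number 1.5 percentage points lower from compound 3 to compound 4 (within the scatter).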

Compound 4, a percentage reported as inhibition, at one concentration (the size of the read-out at that concentration, not a potency): 29.6%
For compound 4 the middle estimate is 3.4 percentage points above the measured one; measured number inside the range.
By their numbers in this assay, from the lowest: compounds 4, 3, 2 and 1 (each within the scatter of the next, the first and the last beyond it).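

In this assay the swap of 4-cyanophenyl for methyl on the amine nitrogen in a ring gives a number 4.9 percentage points lower from compound 3 to compound 4 (within the scatter) and so does not separate the two groups, although one brings 8 heavy atoms and an aromatic ring and the other a single carbon. For the compounds shown here, on the thiocarbonyl carbon, 4-methylpiperazin-1-yl in place of 1,2,3,4-tetrahydroquinolin-1-yl gives a number 8.9 percentage points lower from compound 2 to compound 4 (within the scatter) while the same group in place of 2,3-dihydro-1H-indol-1-yl gives a number 14.4 percentage points lower from compound 1 to compound 4 (beyond the scatter) and this is the first step to clear the scatter, though only modestly. Nothing available explains these numbers.

On these data alone, how a hydrogen, a hydroxyethyl chain or a longer alkyl chain on that ring nitrogen would read remains open. So does whether a carboxylic acid on the 4-cyanophenyl ring would change the picture.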